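Carbamoyl in Place of Methyl: A Permeability Outlook

The source may hold more compounds than are shown below. What is called first, only, known or untested is meant among the compounds shown, and "the series" means these compounds.

Of the compounds shown here, three sharing one core have been measured in an ADME assay on MDCKII-LE cells (Canis lupus familiaris) for permeability, in the apical to basolateral direction; a higher number here means that the compound crosses the layer faster, a lower number that the compound crosses the layer more slowly. Compound 1 `Fc1ccccc1Cc1nc(-c2nc(C(F)(F)F)n[nH]2)c2ccccn12` gives 17 10^-6 cm/s, and compound 3 `Fc1ccccc1Cc1nc(-c2nc(C(F)(F)F)n[nH]2)n2cccnc12` gives 28 10^-6 cm/s. Compound 2 `Cc1n[nH]c(-c2nc(Cc3ccccc3F)c3ccccn23)n1` gives 1 10^-6 cm/s in this assay, the lowest of the three numbers; compound 1 stands nearest to it and compound 3 furthest, both gaps lying beyond the usual scatter. Among the measured compounds shown here, no pair of these three differs in only one place, so no single structural step can be read from them.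

Compound 4 `NC(=O)c1n[nH]c(-c2nc(Cc3ccccc3F)c3ccccn23)n1` has not yet been measured. It differs from compound 2 in one way: carbamoyl in place of methyl on an aromatic carbon. The methyl leaves and the carbamoyl enters on the aromatic carbon of the five-membered aromatic ring, between two ring nitrogen atoms.

Since compound 2 already gives 1 10^-6 cm/s, compound 4 is expected to give a lower number, the estimated step being a 2.5-fold lower number from compound 2 to compound 4 (0.40 log units; beyond the scatter), beyond the scatter. Compound 4 is estimated at 0.4 10^-6 cm/s, within a range from 0.1 10^-6 cm/s to 1.5 10^-6 cm/s, with a fair chance that the assay reports only a limit.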

Compound 4, apparent permeability: 13 10^-6 cm/s
Estimate against measurement, compound 4: 33-fold (1.51 log units) below; measured number above the stated range.
By their numbers in this assay, from the lowest: compound 2; then compounds 4, 1 and 3 (each within the scatter of the next, the first and the last beyond it).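

In this assay, among the compounds shown here, carbamoyl in place of methyl on the aromatic carbon between two ring nitrogen atoms gives a 13-fold higher number from compound 2 to compound 4 (1.11 log units; beyond the scatter) and provides the first single-place step. It shows that the number is highly sensitive to the group at this position, which compounds 1, 2 and 3 could not show because no two of them differ in only one place. In this pair, the entering carbamoyl brings one hydrogen-bond donor and one hydrogen-bond acceptor where methyl has none, and the number still rises. Nothing shown here explains why the number moves this way at this position.

A single step cannot say where other groups at this position, such as a carboxylic acid, an amine or a longer chain, would fall. It also leaves open whether the same change would give a step of similar size on the core of compound 3.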